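The compounds below may be only part of what the source reports. "The series", "measured", "known", "first", "only" and "open" are said of these compounds alone.

Compound 3 `CCN(Cc1c(C(F)(F)F)nc2n1CCCN2c1c(C)cc(C)cc1C)CC1CC1` gives 31 nM in an in vitro assay on IMR-32 cells for displacement of a labelled ligand from corticotropin-releasing factor receptor 1 (Homo sapiens) (a higher number here means a weaker inhibitor, a lower number a stronger inhibitor), the smallest of the three numbers shown, although compound 2 `CCCN(Cc1c(C(F)(F)F)nc2n1CCCN2c1c(C)cc(C)cc1C)CC1CC1` at 32 nM lies within the scatter of it; compound 1 `CCCN(CC1CCC1)C(=O)c1c(C)nc2n1CCCN2c1c(C)cc(C)cc1C` gives 3300 nM, a far higher number. Compound 4 `Cc1cc(C)c(N2CCCn3c2nc(C(F)(F)F)c3CN2CC=CCC2)c(C)c1` differs from compound 3 by a group of 6 heavy atoms (5 carbon, 1 nitrogen; one six-membered non-aromatic ring with 1 hetero atom) in place of a group of 7 heavy atoms (6 carbon, 1 nitrogen; one three-membered non-aromatic ring of carbon only), on a saturated chain carbon bound to an aromatic carbon. Going by the values given here, no measured step exchanges the amine group in this way. Among the compounds with values here, the only step touching that group, a 1.0-fold lower number from compound 2 to compound 3 (0.01 log units; within the scatter), shows that a small change within the amine left this assay unchanged; replacing the whole amine by a ring is a larger and untested change, so a modest rise in the number is expected rather than none. Compound 4 is therefore estimated at 70 nM, between 20 nM and 250 nM. That expectation amounts to a 2.3-fold higher number from compound 3 to compound 4 (0.35 log units; beyond the scatter).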

Compound 4, inhibition constant: 364 nM
Estimate against measurement, compound 4: 5.2-fold (0.72 log units) below; the whole stated range lies below it.
By their numbers in this assay, from the lowest: compounds 3 and 2 (each within the scatter of the next); then compound 4; then compound 1.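

In this assay, this position on a saturated chain carbon bound to an aromatic carbon is not indifferent to the amine: the earlier trimming within the open chain changed nothing, whereas the six-membered ring with its double bond gives a 12-fold higher number from compound 3 to compound 4 (1.07 log units; beyond the scatter) and an 11-fold higher number from compound 2 to compound 4 (1.06 log units; beyond the scatter) as well. Going by these compounds alone, both steps lie beyond the scatter, so the amine's form matters here more than the earlier compounds showed. No evidence given here accounts for this. From the compounds shown here alone, what remains open is whether the ring or its double bond carries the change, and a piperidine or a morpholine at this position would bear on that.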